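A few compounds are considered here, and "the series" means these few. Any claim that something is new, unique, unknown or untested is made for them only; others in the source may bear on it.

Measured in an ADME assay on microsomes from liver (Rattus norvegicus) for metabolic stability, read by LC-MS, with a stated time of 1 h, at 37 degrees C, tested at 4 uM; on this read-out higher numbers stand for a more stable compound and lower numbers for a less stable compound:
- compound 1 `COc1ccc(C(=O)O)cc1-c1cccc(COc2ccc3c(c2)CN(C2CCCC2)C3=O)c1`: 30%
- compound 2 `O=C1c2ccc(OCc3cccc(-c4ccc(C(F)(F)F)cc4F)c3)cc2CN1C1CCCC1`: "not determined" (no result reported)
- compound 3 `COc1ccc(-c2cccc(COc3ccc4c(c3)CN(C3CCCC3)C4=O)c2)cc1C(=O)O`: 84%

Only two of these compounds have numbers, and compound 3, at 84%, holds the higher of them. The next compound, compound 4 `O=C(O)c1ccc(-c2cccc(COc3ccc4c(c3)CN(C3CCCC3)C4=O)c2)c(Cl)c1`, has not yet been measured. It alters the same aromatic ring: 4-carboxy-2-chlorophenyl in place of 3-carboxy-4-methoxyphenyl on an aromatic carbon. In words, 4-carboxy-2-chlorophenyl stands in place of 3-carboxy-4-methoxyphenyl on an aromatic carbon.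

Within the data shown here, one measured step bears on this change, and only indirectly. It is a number 54 percentage points higher from compound 1 to compound 3 (beyond the scatter), a large step beyond the scatter, with 3-carboxy-4-methoxyphenyl in place of 5-carboxy-2-methoxyphenyl. Among the measured compounds shown here, it shows that the number can move far when only this ring differs. However, no measured compound carries the chlorine, and none has its carboxy group numbered 4 in the group's name. The names of compound 1 and compound 4 do share a substituent numbered 2, and compound 1 gives only 30%. On that thin evidence, a fall beyond the scatter but smaller than the measured step is expected in this assay. The expected change is a number 22 percentage points lower from compound 3 to compound 4 (beyond the scatter).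

For compound 4 the estimated value is 62%, within an expected range of 35% to 88%.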

Compound 4, percent of the compound remaining: 3%
Estimate against measurement, compound 4: 59 percentage points above; the measured number lies below the stated range.
By their numbers in this assay, from the lowest: compound 4; then compound 1; then compound 3.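

In this assay the exchange of 3-carboxy-4-methoxyphenyl for 4-carboxy-2-chlorophenyl is a steep loss, with a number 81 percentage points lower from compound 3 to compound 4 (beyond the scatter) exceeding in size the earlier a number 54 percentage points higher from compound 1 to compound 3 (beyond the scatter) seen between the two methoxy-bearing rings. The result also reaches past the lower of those earlier compounds, with a number 27 percentage points lower from compound 1 to compound 4 (beyond the scatter) showing that the 5-carboxy-2-methoxyphenyl ring was not the floor for this position, and that among these three compounds a carboxy-bearing ring on this aromatic carbon, meta to a large group, can give a high number or a very low one. No measurement offered here accounts for these steps.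

Compound 4 differs from compound 3 in the chlorine, the loss of the methoxy group and the place of the carboxy group all at once, so these compounds cannot say which of these changes carries the fall. As far as these compounds go, it also stays open whether a simple 4-carboxyphenyl ring without chlorine, or a ring with a primary amide in place of the carboxylic acid, would sit nearer compound 3 or compound 4 on this read-out.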